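Compound 3 gives up its cyclopentyl group

A few compounds are considered here, and "the series" means these few. Any claim that something is new, unique, unknown or untested is made for them only; others in the source may bear on it.

In a physicochemical assay for solubility, at pH 7.4 (a lower number here means a less soluble compound, a higher number a more soluble compound), compound 1 (`CC(C)(C)c1cc(Nc2ccc(Cl)cc2Cl)ncc1C(=O)NCC1CCOCC1`) stands at 23 ug/mL and compound 2 (`O=C(NCC1CCOCC1)c1cnc(Nc2cc(Cl)cc(Cl)c2)cc1C1CC1`) stands at 7 ug/mL on the same scale. Compound 3 (`O=C(NCC1CCOCC1)c1cnc(Nc2ccc(Cl)cc2Cl)cc1C1CCCC1`) returns only a limit (< 1 ug/mL) and no number.

Compound 4 (`CC(C)(O)c1cc(Nc2ccc(Cl)cc2Cl)ncc1C(=O)NCC1CCOCC1`) is compound 3 with one change (1-hydroxy-1-methylethyl in place of cyclopentyl on an aromatic carbon): 1-hydroxy-1-methylethyl in place of cyclopentyl on an aromatic carbon. Among the measured compounds shown here, the one measured step that bears on this swap is large and beyond the scatter (an at least 23-fold lower number from compound 1 to compound 3 (1.36 log units; beyond the scatter)), and in it cyclopentyl came in where tert-butyl had been. Compound 4 gives up cyclopentyl for a group with no ring, so with that step (an at least 23-fold lower number from compound 1 to compound 3 (1.36 log units; beyond the scatter)) as the guide, a large change of similar size is expected, this time toward a higher number. In this assay the estimated step therefore runs upward (an at least 40-fold higher number from compound 3 to compound 4 (1.60 log units; beyond the scatter)) and is expected to lie beyond the scatter. Compound 4 is expected at 40 ug/mL with a range of 10 ug/mL to 150 ug/mL in this estimate.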

Compound 4, solubility: 150 ug/mL
Estimate against measurement, compound 4: 3.8-fold (0.57 log units) below; measured number inside the range.
By their numbers in this assay, from the lowest: compound 2; then compound 1; then compound 4. At a limit, below all of these: compound 3.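

Up to now, the only step at this position was a drop, seen when cyclopentyl replaced tert-butyl; the result shows that the number in this assay can also rise past the level of the tert-butyl compound. With hydroxy in place of a single methyl on the chain carbon, the step is a 6.5-fold higher number from compound 1 to compound 4 (0.81 log units; beyond the scatter), and against the cyclopentyl compound, where the ring also leaves, it is an at least 150-fold higher number from compound 3 to compound 4 (2.17 log units; beyond the scatter). The value of compound 3 is a limit and not a number: the limit of < 1 ug/mL in this assay, at which 1 of the 4 values shown sits.

Still open, on these data alone, is whether this rise is particular to hydroxy, or whether an amine or a carboxylic acid on the same chain carbon, or a longer chain carrying the hydroxy, would do the same. Also open, as far as these compounds go, is whether the swap carries over to compound 2, which differs from compound 4 in more than one place.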